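A few compounds are considered here, and "the series" means these few. Any claim that something is new, unique, unknown or untested is made for them only; others in the source may bear on it.

Compound 1 `CC(C)N(Cc1cccc(OCCCCCC(=O)O)c1)C(=O)c1ccccc1` is the parent of the set. In an ADME assay on HEK293 cells (Homo sapiens) for cytotoxicity, read by CellTiter-Glo and resazurin assay, with a stated time of 72 h (on this read-out higher numbers stand for an effect only at larger amounts of compound and lower numbers for an effect already at smaller amounts), compound 1 gives only a limit, > 26000 nM. Compound 2 `CC(C)N(Cc1cccc(OCCCCCC(=O)O)c1)C(=O)c1ccc(-c2ccco2)cc1` adds furan-2-yl on an aromatic carbon; in this assay compound 2 likewise gives only a limit, > 26000 nM. Compound 3 `CC(C)N(Cc1cccc(OCCCCCC(=O)O)c1)C(=O)c1ccc(-c2cccc(F)c2)cc1` instead carries 3-fluorophenyl on an aromatic carbon; in this assay compound 3 again gives only a limit, > 26000 nM. The steps among the three are a step that the two limits leave unreadable from compound 1 to compound 2, a step that the two limits leave unreadable from compound 1 to compound 3 and a step that the two limits leave unreadable from compound 2 to compound 3; none of them can be sized, since (the limit of > 26000 nM in this assay, at which 3 of the 3 values shown sit). Compound 3 thus stands at the limit, as do the two other values in this assay.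

Compound 4 `CC(C)N(Cc1cccc(OCCCCCC(=O)O)c1)C(=O)c1ccc(-c2cccc(C(F)(F)F)c2)cc1` differs from compound 3 by trifluoromethyl in place of fluoro on an aromatic carbon. The measured steps that bear on this change are the three above, each unreadable at the limit, and none shows an effect inside the measured range for any member of the series. The step is therefore expected to be a step that the limit leaves unreadable from compound 3 to compound 4, no more than scatter. For compound 4 the estimate in this assay is 30000 nM, with a range from 15000 nM to 100000 nM, most likely reported again as a limit.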

Compound 4, half-maximal effective concentration: > 26000 nM
Compound 4 gave a limit, no number; the forecaster's own chance of this, stated with the estimate: 85%; the middle value does not contradict the limit.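

The steps from compound 1, compound 2 and compound 3 to compound 4 cannot be read, as all four compounds sit at the same limit in this assay: the limit of > 26000 nM in this assay, at which 4 of the 4 values shown sit.

The compounds shown leave open at what concentration any of them has an effect in this assay, and whether furan-2-yl, 3-fluorophenyl or 3-(trifluoromethyl)phenyl alters it.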